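A few compounds are considered here, and "the series" means these few. Any claim that something is new, unique, unknown or untested is made for them only; others in the source may bear on it.

Measured compounds in the series so far:

Compound 1 `O=S(=O)(/C=C/c1ccccn1)c1ccccc1Cl` — 618 nM
Compound 2 `O=S(=O)(/C=C/c1ncccc1F)c1ccccc1Cl` — 122 nM

In an assay on U2OS cells for activation of nuclear factor erythroid 2-related factor 2 (Homo sapiens), read by beta-arrestin recruitment, with a stated time of 6 h (on this read-out higher numbers stand for an effect only at larger amounts of compound and lower numbers for an effect already at smaller amounts), compound 1 gives 618 nM, the highest of the two numbers; its nearest neighbour is compound 2, reached by a 5.1-fold lower number from compound 1 to compound 2 (0.70 log units; beyond the scatter), a modest step and one that lies beyond the scatter. Going by the values given here, that step is a fluoro in place of hydrogen on an aromatic carbon, the only measured step available.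

Compound 3 `O=S(=O)(/C=C/c1ccncc1)c1ccccc1Cl` has not yet been measured. It differs from compound 1 as pyridin-4-yl in place of pyridin-2-yl on a double-bonded chain carbon bound to a double-bonded chain carbon — the two have the same atoms, joined differently. Among the compounds with values here, no measured step concerns this kind of change: the step from compound 1 to compound 2 alters a substituent rather than the arrangement of the heteroaryl, so it offers no direct guide. On what is in hand, the expectation for compound 3 in this assay is therefore a number near that of compound 1, with no step beyond the scatter anticipated in either direction, the estimated step being a 1.1-fold higher number from compound 1 to compound 3 (0.05 log units; within the scatter). Compound 3 is estimated at 700 nM, with a range from 200 nM to 2500 nM reflecting the lack of a bearing step.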

Compound 3, half-maximal effective concentration: 781 nM
The estimate for compound 3 lay 1.1-fold (0.05 log units) below the measured number; the measured number falls inside the stated range.
By their numbers in this assay, from the lowest: compound 2; then compounds 1 and 3 (each within the scatter of the next).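

In this assay, pyridin-4-yl in place of pyridin-2-yl on a double-bonded chain carbon bound to a double-bonded chain carbon gives a 1.3-fold higher number from compound 1 to compound 3 (0.10 log units; within the scatter), so this read-out does not separate these two groups at this place. Going by these compounds alone, the only earlier step, a fluoro in place of hydrogen on an aromatic carbon, gave a 5.1-fold lower number from compound 1 to compound 2 (0.70 log units; beyond the scatter) and lies beyond the scatter, whereas rejoining the same atoms as pyridin-4-yl leaves the number of compound 3 within the scatter of that of compound 1. No supporting data bear on why this pair reads alike.

Open questions remain on whether the fluoro step carries over to pyridin-4-yl, and whether pyridin-3-yl, a plain phenyl or an amine-bearing pyridine would also read alike at this place. As far as these compounds go, the chloro substituent is common to all three compounds, so the effect of a methoxy group in its place remains unknown.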